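Moving the Methoxy Group on a Thiourea Scaffold

The compounds below may be only part of what the source reports. "The series", "measured", "known", "first", "only" and "open" are said of these compounds alone.

Compound 1 `COc1ccccc1NC(=S)NC1CC(C)(C)Oc2ccc(Br)cc21` was examined in a functional assay on T98G cells (Homo sapiens) for inhibition, read by MTT assay, with a stated time of 72 h (a higher number here means a weaker inhibitor, a lower number a stronger inhibitor), where compound 1 gives 42000 nM. Among the two numbers recorded, this is the highest. Within the data shown here, the only other measured compound, compound 2 `CC1(C)CC(NC(=S)Nc2ccc([N+](=O)[O-])cc2)c2cc(Cl)ccc2O1`, differs from compound 1 in more than one place, so no single change links them; in this assay compound 2 gives 4000 nM, a number lower than that of compound 1 by a margin that lies beyond the usual scatter, which makes compound 1 the weaker inhibitor of the pair.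

Compound 3 `COc1ccc(NC(=S)NC2CC(C)(C)Oc3ccc(Br)cc32)cc1` has the same atoms as compound 1, joined differently: 4-methoxyphenyl in place of 2-methoxyphenyl on an amide-type nitrogen. Among the measured compounds shown here, no measured pair shows this change, so its size cannot be read from the data. Compound 1 stands at the high end of the numbers seen, so a step toward a lower number is expected for compound 3, but only a modest one, not far from the scatter of the method, with an estimated value of 30000 nM and a range from 8000 nM to 110000 nM. This expectation amounts to a step of a 1.4-fold lower number from compound 1 to compound 3 (0.15 log units; within the scatter).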

Compound 3, half-maximal inhibitory concentration: 33000 nM
For compound 3 the middle estimate is 1.1-fold (0.04 log units) below the measured one, within the range that was stated.
By their numbers in this assay, from the lowest: compound 2; then compounds 3 and 1 (each within the scatter of the next).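

In this assay, among these compounds, the change of 2-methoxyphenyl to 4-methoxyphenyl on an amide-type nitrogen whose other neighbour is the thiocarbonyl carbon is the only single change available, and the step is a 1.3-fold lower number from compound 1 to compound 3 (0.10 log units; within the scatter) and so gives no real difference between the two placements. This adds what the earlier pair of compounds could not show: with the shared core held fixed and the atoms unchanged, moving the methoxy group on the phenyl ring does not separate compound 1 from compound 3 in this assay, and both remain in the same range of numbers. Nothing available bears on why the two placements read alike.

As far as these compounds go, it remains open whether any other group at this position would shift the number beyond the scatter, for instance an amine, a carboxylic acid or a longer chain such as butoxy in place of the methoxy group. Compound 2 at 4000 nM differs from compound 1 and from compound 3 in more than one place, so which of its differences goes with its lower number also stays unresolved.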